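From Piperidin-1-yl to 3-Oxomorpholin-4-yl: A Small Step Expected

The source may hold more compounds than are shown below. What is called first, only, known or untested is meant among the compounds shown, and "the series" means these compounds.

Measured so far in an in vitro ADME assay on microsomes from liver (Mus musculus) for metabolic stability; on this read-out higher numbers stand for a longer-lived compound and lower numbers for a shorter-lived compound:
Compound 1 `O=C1COCCN1c1ccc(C2CC(c3ccc([N+](=O)[O-])o3)=NO2)cn1` gives 1.01 h
Compound 2 `O=[N+]([O-])c1ccc(C2=NOC(c3ccc(N4CCCCC4)cc3)C2)o1` gives 0.78 h
Compound 3 `CN1CCN(c2ccc(C3CC(c4ccc([N+](=O)[O-])o4)=NO3)cn2)C(=O)C1` gives 0.35 h

The numbers for compound 2 and compound 1 lie within the usual scatter of each other, so these two cannot be ranked. Both stand above compound 3, and the gap between compound 2 and compound 3 lies beyond the scatter.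

Compound 4 `O=C1COCCN1c1ccc(C2CC(c3ccc([N+](=O)[O-])o3)=NO2)cc1` has not yet been measured. It differs from compound 2 by 3-oxomorpholin-4-yl in place of piperidin-1-yl on an aromatic carbon, para to a large group (3-oxomorpholin-4-yl in place of piperidin-1-yl on an aromatic carbon).

Within the data shown here, only one measured step bears on this change, and only indirectly. Replacing 3-oxomorpholin-4-yl with 4-methyl-2-oxopiperazin-1-yl gives a 2.9-fold lower number from compound 1 to compound 3 (0.46 log units; beyond the scatter) and shows a modest move in that pair. That step does not involve piperidin-1-yl, so it cannot set the size of the step to compound 4. The closer guide is compound 1 (1.01 h), which also carries 3-oxomorpholin-4-yl, though on a different aromatic ring. Compound 4 is therefore expected to land near compound 1.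

The expected change is a 1.3-fold higher number from compound 2 to compound 4 (0.11 log units; within the scatter) and no clear shift in either direction is anticipated. The estimated value for compound 4 in this assay is 1 h (expected range 0.5 h to 2 h).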

Compound 4, half-life in the liver assay: 1.4 h
Compound 4: middle estimate off by 1.4-fold (0.15 log units), on the low side, and the stated range covers the measured number.
By their numbers in the liver assay, from the lowest: compound 3; then compounds 2, 1 and 4 (each within the scatter of the next).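

Among these compounds, this pair gives the first direct reading of the exchange of piperidin-1-yl for 3-oxomorpholin-4-yl on an aromatic carbon, para to a large group, since the earlier compounds offered only indirect guidance on it. In the liver assay, the exchange gives a 1.8-fold higher number from compound 2 to compound 4 (0.25 log units; within the scatter), so the two compounds cannot be ranked on half-life, and this place tolerates the larger, more heteroatom-rich group without a clear shift in that read-out. Among the compounds shown here, the separation between the two appears in another property, which the earlier compounds did not address. In a physicochemical assay for solubility, with a stated time of 18 h, at pH 7.4 (a higher number here means a more soluble compound, a lower number a less soluble compound), compound 2 gives 1.1 ug/mL and compound 4 gives 25.9 ug/mL, and there the step is large: the measured solubility of compound 2, 1.1 ug/mL, and of compound 4, 25.9 ug/mL, a 24-fold higher number (1.37 log units; beyond the scatter)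

What the compounds shown leave open is which part of 3-oxomorpholin-4-yl goes with this solubility step, since the entering group differs from piperidin-1-yl in both its ring oxygen and its carbonyl, and morpholin-4-yl or 2-oxopiperidin-1-yl at the same place would pull those two apart. As far as these compounds go, it also remains open whether 4-methyl-2-oxopiperazin-1-yl, seen here only on the other aromatic ring, would give the same half-life on the ring of carbon only.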